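A methyl for a chloro in compound 4

The compounds below may be only part of what the source reports. "The series", "measured", "known", "first", "only" and "open" are said of these compounds alone.

Measured compounds and their values in a functional assay (plasma) for inhibition, with Homo sapiens as the target; a lower number here means a stronger inhibitor, a higher number a weaker inhibitor
Compound 1 `O=C(O)CCC/C=C\C[C@@H]1[C@H](O)CC[C@H]1NS(=O)(=O)c1ccc(Cl)cc1` gives 2200 nM
Compound 2 `O=C(O)CCC/C=C\C[C@@H]1[C@@H](NS(=O)(=O)c2ccc(Cl)cc2)CC[C@@H]1O` gives 190 nM
Compound 3 `O=C(O)CC/C=C\C[C@@H]1[C@@H](NS(=O)(=O)c2ccc(Cl)cc2)CC[C@@H]1O` gives 1800 nM

Compound 1 cannot be told apart from compound 3 in this assay and stands clearly apart only from compound 2, with a 12-fold lower number from compound 1 to compound 2 (1.06 log units; beyond the scatter) as the step between them. The only structural difference in that step is given by the fact that compounds 1 and 2 differ only in the configuration as drawn and no other.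

Compound 4 `Cc1ccc(S(=O)(=O)N[C@@H]2CC[C@@H](O)[C@H]2C/C=C\CCCC(=O)O)cc1` keeps the core of compound 1 and carries one change methyl in place of chloro on an aromatic carbon with methyl in place of chloro on an aromatic carbon, para to a large group. Neither measured step tests this exchange. The first, a 12-fold lower number from compound 1 to compound 2 (1.06 log units; beyond the scatter) concerns configuration only, and the second, a 9.5-fold higher number from compound 2 to compound 3 (0.98 log units; beyond the scatter) concerns the chain. The step to compound 4 is therefore expected to stay within the scatter in this assay. The reference remains compound 1 at 2200 nM as the closest measured neighbour. Compound 4 is estimated at 2500 nM with an expected range from 800 nM to 8000 nM in this assay. The estimated change is a 1.1-fold higher number from compound 1 to compound 4 (0.06 log units; within the scatter) by this expectation.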

Compound 4, half-maximal inhibitory concentration: 5800 nM
Compound 4: the middle estimate sits 2.3-fold (0.37 log units) below what was measured; low and high end bracket the measured number.
By their numbers in this assay, from the lowest: compound 2; then compounds 3 and 1 (each within the scatter of the next); then compound 4.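

In this assay, within the data shown here, the exchange of 4-chlorophenyl for 4-methylphenyl gives a 2.6-fold higher number from compound 1 to compound 4 (0.42 log units; beyond the scatter) and so is the first change at this aromatic carbon that can be read. With the configuration and chain of compound 1 held fixed, one heavy atom replaces another, neither group carries a hydrogen-bond donor or acceptor, and the number still moves beyond the scatter, with chloro giving the lower number of the two. The one fact on record concerns configuration, not this exchange, so nothing here accounts for the step.

The compounds shown leave open whether fluoro, methoxy or trifluoromethyl at this place would read closer to chloro or to methyl. They also leave open whether the same exchange on compound 2, which gives 190 nM in this assay and carries the other configuration, would move the number by a similar amount.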